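Replacing one trifluoromethyl by carbamoyl on the anilide ring

A few compounds are considered here, and "the series" means these few. Any claim that something is new, unique, unknown or untested is made for them only; others in the source may bear on it.

Of the compounds shown here, three have been measured in an assay on Jurkat cells for inhibition of nuclear factor NF-kappa-B p105 subunit (Homo sapiens); a higher number here means a weaker inhibitor, a lower number a stronger inhibitor. Compound 1, `O=C(Nc1cc(Cl)cc(Cl)c1)c1cnc(N2CCCCC2)nc1C(F)(F)F`, gives 5000 nM in this assay. Compound 2, `Cc1ccc(NC(=O)c2cnc(Cl)nc2C(F)(F)F)s1`, gives 2300 nM in this assay. Compound 3, `O=C(Nc1cc(C(F)(F)F)cc(C(F)(F)F)c1)c1cnc(Cl)nc1C(F)(F)F`, gives 50 nM in this assay, the lowest of the three numbers; its nearest neighbour is compound 2, whose value is higher by an amount beyond the scatter, and compound 1 lies further away still, also beyond the scatter. Compound 3 is therefore the strongest inhibitor among the three.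

Compound 4, `NC(=O)c1cc(NC(=O)c2cnc(Cl)nc2C(F)(F)F)cc(C(F)(F)F)c1`, has not yet been measured in this assay. It differs from compound 3 in one place: carbamoyl in place of trifluoromethyl on an aromatic carbon. Going by the values given here, no pair of measured compounds differing only in this way is available, so the size of the step can only be guessed from where compound 3 stands. The account expects compound 4 to lose some potency relative to compound 3, since the bis-trifluoromethyl ring of compound 3 accompanies its value of 50 nM, and the expected step from compound 3 to compound 4 is a 6.0-fold higher number from compound 3 to compound 4 (0.78 log units; beyond the scatter), a weakening beyond the scatter but not a collapse. For compound 4 the estimate in this assay is 300 nM, with a range from 60 nM to 1500 nM.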

Compound 4, half-maximal inhibitory concentration: 5000 nM
For compound 4 the middle estimate is 17-fold (1.22 log units) below the measured one; the whole stated range lies below it.
By their numbers in this assay, from the lowest: compound 3; then compound 2; then compounds 1 and 4 (each within the scatter of the next).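

In this assay, carbamoyl in place of trifluoromethyl on an aromatic carbon gives a 100-fold higher number from compound 3 to compound 4 (2.00 log units; beyond the scatter), and this large step is the only one in the series that can be read between two compounds differing in one place. Where the earlier values could not isolate any single position, this pair shows that the place on the six-membered aromatic ring of carbon only, meta to a trifluoromethyl group, is highly sensitive to this exchange, even though compound 3 and compound 4 share the core and keep the other trifluoromethyl group. No measurement at hand bears on the reason for a step of this size.

This single exchange does not separate what is lost with the departure of trifluoromethyl from what the entry of carbamoyl contributes. From the compounds shown here alone, how a nitrile, a methyl group, a chlorine atom, a carboxylic acid or an amine at this same place would read in this assay remains open, and so does whether the other trifluoromethyl group would respond to the same exchange in the same way.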